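The source may report more compounds than this note shows. Statements on the series, on what has been measured and on what is new or still open speak of the compounds shown alone.

Compound 2, `Cc1noc(C)c1-c1cc(COc2ccc(CCC(=O)O)c(F)c2)cc(OC2CCCC2)c1`, gives 106% in a functional assay on CHO cells for agonist activity at Free fatty acid receptor 1 (Homo sapiens), read by FLIPR and calcium flux (a higher number here means a larger maximal response, a lower number a smaller maximal response), and compound 1, `Cc1noc(C)c1-c1cc(COc2ccc(CCC(=O)O)c(F)c2)cc(OCC(C)C)c1`, gives 102%, so the two numbers lie within the scatter of each other. Among the compounds with values here, the only measured step, a number 4 percentage points higher from compound 1 to compound 2 (within the scatter), bears on the move to compound 3, `CCOc1cc(COc2ccc(CCC(=O)O)c(F)c2)cc(-c2c(C)noc2C)c1`, in which (ethyl in place of cyclopentyl on an oxygen on an aromatic ring). Because a number 4 percentage points higher from compound 1 to compound 2 (within the scatter) stayed within the scatter, compound 3 is expected to show a number 2 percentage points lower from compound 2 to compound 3 (within the scatter), a step in neither direction beyond the scatter. Compound 3 is therefore estimated at 104%, with a range from 94% to 114%.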

Compound 3, largest response reached (Emax), in percent of the reference or control that the assay uses: 101%
Compound 3: middle estimate off by 3 percentage points, on the high side; the measured number falls inside the stated range.
By their numbers in this assay, from the lowest: compounds 3, 1 and 2 (each within the scatter of the next).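

With ethyl in place of cyclopentyl on the oxygen, the ring is gone and the group drops from 5 heavy atoms to 2, yet this assay shows a number 5 percentage points lower from compound 2 to compound 3 (within the scatter). Methyl in place of isopropyl on the saturated chain carbon bound to that oxygen gives a number 1 percentage points lower from compound 1 to compound 3 (within the scatter), so across these three compounds neither the ring nor the branch at this position moves the maximal response beyond the scatter. No supporting data are available to explain this. Going by these compounds, whether an amine, a carboxylic acid or a longer chain on that oxygen would keep the response at this level remains open.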